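Series notes: amine substituent on the pyridyl ring of the shared core

The source may report more compounds than this note shows. Statements on the series, on what has been measured and on what is new or still open speak of the compounds shown alone.

Measured so far:
compound 1 `CC(C(=O)NCc1ccc(C(F)(F)F)nc1Nc1ccccc1)c1ccc(NS(C)(=O)=O)c(F)c1` — 1400 nM
compound 2 `COC1CCN(c2nc(C(F)(F)F)ccc2CNC(=O)C(C)c2ccc(NS(C)(=O)=O)c(F)c2)CC1` — 280 nM

In a functional assay on CHO-K1 cells for antagonist activity at transient receptor potential cation channel subfamily V member 1 (Homo sapiens), read by FLIPR (on this read-out lower numbers stand for stronger inhibition and higher numbers for weaker inhibition), compound 2 gives 280 nM, the lowest of the two numbers; its nearest neighbour is compound 1, which gives 1400 nM. Among the compounds with values here, the only measured step in this assay is a 5.0-fold lower number from compound 1 to compound 2 (0.70 log units; beyond the scatter), where a saturated cyclic amine replaced the anilino group.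

Compound 3 `CC(C(=O)NCc1ccc(C(F)(F)F)nc1N1CCCCCC1)c1ccc(NS(C)(=O)=O)c(F)c1` differs from compound 2 by azepan-1-yl in place of 4-methoxypiperidin-1-yl on an aromatic carbon. Within the data shown here, no measured step exchanges one saturated cyclic amine for another, so the step from compound 1 to compound 2 bears only indirectly: both compound 2 and compound 3 carry such an amine on the shared core. Against that background no step beyond the scatter is expected from compound 2 to compound 3 in this assay, with a 1.1-fold higher number from compound 2 to compound 3 (0.03 log units; within the scatter) as the estimated step. For compound 3 the estimate is 300 nM, within the range 100 nM to 900 nM.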

Compound 3, half-maximal inhibitory concentration: 25.1 nM
Beside the measured number, compound 3's estimate is 12-fold (1.08 log units) above it; measured number outside the range, below it.
By their numbers in this assay, from the lowest: compound 3; then compound 2; then compound 1.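

Exchanging 4-methoxypiperidin-1-yl for azepan-1-yl gives an 11-fold lower number from compound 2 to compound 3 (1.05 log units; beyond the scatter) in this assay and so shows that this position, next to the ring nitrogen, distinguishes between saturated cyclic amines and does not merely favour them as a class over anilino. Against anilino, azepan-1-yl gives a 56-fold lower number from compound 1 to compound 3 (1.75 log units; beyond the scatter) on the same read-out, the widest gap among the three compounds. Nothing available accounts for the difference between the two amines.

The change from compound 2 to compound 3 alters ring size and removes the methoxy group in one step, so the two contributions cannot be separated here. Unsubstituted piperidin-1-yl would divide that step, and pyrrolidin-1-yl or a methoxy-bearing azepane would test ring size and the methoxy group further.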